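This account rests on a few compounds, and the source may have more. Where it says the series, first, only, none or still open, it means among the compounds named here.

Measured compounds:
Compound 1 `COc1cc2c(Oc3ccc(NC(=O)c4cn(-c5ccccc5OC)cn4)cc3F)ccnc2cc1OCCCN1CCCCC1` gives 260 nM in a functional assay on MKN-45 cells (Homo sapiens) for cytotoxicity, read by MTT assay, with a stated time of 72 h; on this read-out lower numbers stand for stronger inhibition and higher numbers for weaker inhibition.
Compound 2 `COc1cc2c(Oc3ccc(NC(=O)c4cn(-c5cc(C)ccc5C)cn4)cc3F)ccnc2cc1OCCCN1CCCCC1` gives 830 nM in this assay.
Compound 3 `COc1cc2c(Oc3ccc(NC(=O)c4cn(-c5ccc(Cl)cc5Cl)cn4)cc3F)ccnc2cc1OCCCN1CCCCC1` gives 6240 nM in this assay.

Compound 2 stands second highest of the three numbers. Its nearest neighbour is compound 1, reached by a 3.2-fold higher number from compound 1 to compound 2 (0.50 log units; beyond the scatter) through a change of the aryl group on the ring nitrogen. Its furthest neighbour is compound 3, reached by a 7.5-fold higher number from compound 2 to compound 3 (0.88 log units; beyond the scatter), also a change on that aryl group. The change to compound 4 `COc1cc2c(Oc3ccc(NC(=O)c4cn(-c5cc(C)ccc5C)cn4)cc3F)ccnc2cc1OCCCN1CCC(C)CC1` is a different one: methyl in place of hydrogen on a saturated ring carbon. This change lies on the distant saturated ring rather than on the aryl group, so none of the three measured steps bears on it; all of them concern the aryl group on the ring nitrogen and are of modest to large size. Within the data shown here, with no measured step touching the saturated ring, the expected step in this assay is none beyond the scatter, that is no change at the digits printed from compound 2 to compound 4 (within the scatter). Compound 4 is therefore estimated at 830 nM, within the range 300 nM to 2500 nM.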

Compound 4, half-maximal inhibitory concentration: 5650 nM
Estimate against measurement, compound 4: 6.8-fold (0.83 log units) below, and the stated range ends below it.
By their numbers in this assay, from the lowest: compound 1; then compound 2; then compounds 4 and 3 (each within the scatter of the next).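

Adding a single methyl to the far saturated ring, turning piperidin-1-yl into 4-methylpiperidin-1-yl, gives a 6.8-fold higher number from compound 2 to compound 4 (0.83 log units; beyond the scatter) in this assay and so a weaker result. Among these compounds, the earlier compounds differed only in the aryl group on the ring nitrogen, so this is the first sign that this distant ring also matters in this assay, and that even one added carbon on it, three ring bonds from the ring nitrogen, can shift the number beyond the scatter. Nothing measured here gives a reason for this step.

From the compounds shown here alone, what an ethyl or hydroxyl group would do on this same ring carbon remains open, as does the effect of a morpholine ring in place of the piperidine. Going by these compounds, it is also open whether the methyl has a similar effect alongside the 2-methoxyphenyl group of compound 1.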